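The source may report more compounds than this note shows. Statements on the series, on what has been measured and on what is new or still open speak of the compounds shown alone.

In an assay on CHO cells for displacement of a labelled ligand from adenosine receptor A1 (Homo sapiens), read by scintillation counting, with a stated time of 120 min, tested at 10 uM (a lower number here means less inhibition, a higher number more inhibition at the concentration tested (going by the name of the read-out)), three compounds have been measured:

- compound 1, `Nc1scc(CN2CCN(c3ccc(F)cc3Cl)CC2)c1C(=O)c1ccc(Cl)cc1`, gives 0%
- compound 2, `Nc1scc(CN2CCN(c3ccncc3)CC2)c1C(=O)c1ccc(Cl)cc1`, gives 1%
- compound 3, `Nc1scc(CN2CCN(c3cccc4ccccc34)CC2)c1C(=O)c1ccc(Cl)cc1`, gives 1%

All three share one core and differ only in the group carried on the amine nitrogen in a ring. Compound 3 stands level with compound 2 at the digits printed, and these two sit together at the top of the three numbers; its furthest neighbour is compound 1, and even that gap is small: a number 1 percentage points higher from compound 1 to compound 3 (within the scatter). Among the compounds with values here, in short, every compound so far shows essentially no inhibition in this assay.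

Compound 4, `Nc1scc(CN2CCN(c3cccc(F)c3)CC2)c1C(=O)c1ccc(Cl)cc1`, has not yet been tested. It differs from compound 3 in one place: 3-fluorophenyl in place of naphthalen-1-yl on an amine nitrogen in a ring.

Every measured step bears on this change, since each one also swaps the group on that ring nitrogen. These steps were a number 1 percentage points higher from compound 1 to compound 2 (within the scatter), a number 1 percentage points higher from compound 1 to compound 3 (within the scatter) and no change at the digits printed from compound 2 to compound 3 (within the scatter), and none of them left the scatter. Exchanging one such group for another has therefore made no visible difference, and compound 4 is expected to behave the same way, with a step of no change at the digits printed from compound 3 to compound 4 (within the scatter).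

Compound 4 is accordingly estimated at 1%, with a likely range from -6% to 9%.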

Compound 4, a percentage reported as inhibition, at one concentration (the size of the read-out at that concentration, not a potency): 1%
For compound 4 middle estimate and measured number coincide at the digits printed; measured number inside the range.
By their numbers in this assay, from the lowest: compounds 1, 2, 3 and 4 (each within the scatter of the next).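

In this assay, going from the two aromatic rings of naphthalen-1-yl to the single ring of 3-fluorophenyl leaves the read-out where it was (no change at the digits printed from compound 3 to compound 4 (within the scatter)). The same holds for the swap from the nitrogen-containing ring of pyridin-4-yl (no change at the digits printed from compound 2 to compound 4 (within the scatter)) and for the swap from 2-chloro-4-fluorophenyl, a phenyl ring that carries chlorine as well as fluorine (a number 1 percentage points higher from compound 1 to compound 4 (within the scatter)). All four aromatic groups on this ring nitrogen therefore read alike, so neither ring count nor these halogens has shown any visible effect here.

The compounds shown leave open whether a different kind of group on this nitrogen, such as a carboxylic acid or a longer chain ending in an amine, would move the number. No measurement is available that explains this flat result.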